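Benzamide for Triazole on a Sulfonamide Oxadiazole Series

The source may report more compounds than this note shows. Statements on the series, on what has been measured and on what is new or still open speak of the compounds shown alone.

The measured compounds are:
compound 1, `CN1CCN(Cc2nnc(-c3cc(S(N)(=O)=O)c(SCc4ccccc4)cc3Cl)o2)CC1`, 75000 nM;
compound 2, `NS(=O)(=O)c1cc(-c2nnc(CN3CCN(c4ccccc4)CC3)o2)c(Cl)cc1SCc1ccccc1`, 295000 nM;
compound 3, `NS(=O)(=O)c1cc(-c2nnc(Cn3cc(-c4ccccc4)nn3)o2)c(Cl)cc1SCc1ccccc1`, 170000 nM.

All three were tested in a functional assay on MCF7 cells (Homo sapiens) for cytotoxicity, read by MTT assay, with a stated time of 72 h; a lower number here means a stronger inhibitor, a higher number a weaker inhibitor. Compound 3 stands second highest of the three numbers. Its nearest neighbour is compound 2, a gap that the comparison a 1.7-fold lower number from compound 2 to compound 3 (0.24 log units; within the scatter) places within the scatter, so the two cannot be ordered. Its furthest neighbour is compound 1, and the step of a 2.3-fold higher number from compound 1 to compound 3 (0.36 log units; beyond the scatter) is modest but lies beyond the scatter.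

Compound 4, `NS(=O)(=O)c1cc(-c2nnc(CNC(=O)c3ccccc3)o2)c(Cl)cc1SCc1ccccc1`, is not yet measured. It differs from compound 3 in one place: benzamido in place of 4-phenyl-1H-1,2,3-triazol-1-yl on a saturated chain carbon bound to an aromatic carbon. Among the compounds with values here, two measured steps touch the same position on the shared core. The step of a 2.3-fold higher number from compound 1 to compound 3 (0.36 log units; beyond the scatter) and the step of a 1.7-fold lower number from compound 2 to compound 3 (0.24 log units; within the scatter) show that three quite different groups at this carbon shift the number only modestly in either direction. Within the data shown here, the benzamido group brings one hydrogen-bond donor where the leaving group had none, but no measured pair tests that kind of change here.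

Compound 4 is therefore expected to give a number close to that of compound 3, with the step of no change at the digits printed from compound 3 to compound 4 (within the scatter) not expected to pass beyond the scatter. The estimate for compound 4 is 170000 nM, within a range from 70000 nM to 400000 nM.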

Compound 4, half-maximal inhibitory concentration: 66000 nM
The estimate for compound 4 lay 2.6-fold (0.41 log units) above the measured number, and the stated range ends above it.
By their numbers in this assay, from the lowest: compounds 4 and 1 (each within the scatter of the next); then compounds 3 and 2 (each within the scatter of the next).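

In this assay, within the data shown here, benzamido is the first group at this saturated chain carbon to give a lower number than both 4-phenyl-1H-1,2,3-triazol-1-yl (a 2.6-fold lower number from compound 3 to compound 4 (0.41 log units; beyond the scatter)) and 4-phenylpiperazin-1-yl (a 4.5-fold lower number from compound 2 to compound 4 (0.65 log units; beyond the scatter)), each step lying beyond the scatter. Among the earlier compounds, both groups that end in a six-membered aromatic ring gave higher numbers than 4-methylpiperazin-1-yl, but compound 4 goes against that pattern, for benzamido also carries such a ring and cannot be ordered against 4-methylpiperazin-1-yl (a 1.1-fold lower number from compound 1 to compound 4 (0.06 log units; within the scatter), within the scatter). Nothing in the data shown accounts for the difference between benzamido and the two other ring-bearing groups.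

The compounds shown leave open whether the amide hydrogen matters, which benzamido with a methyl group on its amide nitrogen would test, and whether the benzene ring matters, which acetamido would test. They also leave open whether the lower number of compound 4 would hold if the benzylthio group on the shared core gave way to a methylthio group.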